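The source may hold more compounds than are shown below. What is called first, only, known or untested is meant among the compounds shown, and "the series" means these compounds.

Measured in a toxicity assay on HEK-293T cells (Homo sapiens) for cytotoxicity, read by MTT assay, with a stated time of 72 h; on this read-out lower numbers stand for stronger inhibition and higher numbers for weaker inhibition:
- compound 1 `O=C1c2c[n+]([O-])c3ccccc3c2C(=O)c2c1c1ccccc1n2Cc1cn(C[C@H](O)CO)nn1`: 8880 nM
- compound 2 `CC1(C)O[C@@H](CO)[C@H](Cn2cc(Cn3c4c(c5ccccc53)C(=O)c3c[n+]([O-])c5ccccc5c3C4=O)nn2)O1`: 120 nM
- compound 3 `CC1(C)OC[C@@H](Cn2cc(Cn3c4c(c5ccccc53)C(=O)c3c[n+]([O-])c5ccccc5c3C4=O)nn2)O1`: 6020 nM

Compound 1 stands at the high end of these three numbers. The nearest comparison gives a 1.5-fold lower number from compound 1 to compound 3 (0.17 log units; within the scatter), and the furthest gives a 74-fold lower number from compound 1 to compound 2 (1.87 log units; beyond the scatter).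

Compound 4 `CN1CCN(CCCn2c3c(c4ccccc42)C(=O)c2c[n+]([O-])c4ccccc4c2C3=O)CC1` has not yet been measured. It differs from compound 1 by a single exchange: 2-(4-methylpiperazin-1-yl)ethyl in place of 1-(2,3-dihydroxypropyl)-1H-1,2,3-triazol-4-yl on a saturated chain carbon bound to an aromatic nitrogen. Here, 2-(4-methylpiperazin-1-yl)ethyl takes the place of 1-(2,3-dihydroxypropyl)-1H-1,2,3-triazol-4-yl on a saturated chain carbon bound to an aromatic nitrogen.

The measured steps bear on this only indirectly. Among the measured compounds shown here, they alter the same substituent but keep its triazole, and no measured compound carries the incoming group. Even so, they show how sensitive this place can be, since the further comparison gives a 50-fold higher number from compound 2 to compound 3 (1.70 log units; beyond the scatter). With outcomes ranging from none beyond the scatter to large, a moderate move towards a lower number seems the fairest expectation in this assay, though with wide uncertainty.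

The expected change is a 5.9-fold lower number from compound 1 to compound 4 (0.77 log units; beyond the scatter).

For compound 4 the estimated value is 1500 nM, with an expected range from 200 nM to 8000 nM.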

Compound 4, half-maximal inhibitory concentration: 170 nM
Beside the measured number, compound 4's estimate is 8.8-fold (0.95 log units) above it; measured number below the stated range.
By their numbers in this assay, from the lowest: compounds 2 and 4 (each within the scatter of the next); then compounds 3 and 1 (each within the scatter of the next).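

In this assay the exchange gives a 52-fold lower number from compound 1 to compound 4 (1.72 log units; beyond the scatter), so a large step at this place, on a saturated chain carbon bound to an aromatic nitrogen, does not require the triazole or any hydroxyl group to be kept. Among the earlier compounds, only the 5-(hydroxymethyl)-2,2-dimethyl-1,3-dioxolan-4-yl group of compound 2 had brought a large step down from compound 1, and that group still sat on the triazole. No evidence is available that accounts for this step.

The exchange removes the triazole and the diol and brings in the 4-methylpiperazine all at once, so the compounds shown cannot assign the step to any one of these parts. A morpholine in place of the 4-methylpiperazine, or a dimethylamine on the same chain, would test how much depends on the piperazine ring itself.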